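The compounds below may be only part of what the source reports. "The series", "measured", "known", "first", "only" and "open" are said of these compounds alone.

Measured so far in the series:
compound 1 `Nc1ccccc1NC(=O)c1ccc(CSC(=S)N2CCN(Cc3ccccn3)CC2)cc1`: 20.7%
compound 2 `Nc1ccccc1NC(=O)c1ccc(CSC(=S)N2CCc3ccccc32)cc1`: 25.7%
compound 3 `CC1CCN(C(=S)SCc2ccc(C(=O)Nc3ccccc3N)cc2)CC1`: 32.7%

In a functional assay on A-375 cells (Homo sapiens) for antiproliferative activity, read by CCK-8 assay, with a stated time of 72 h, tested at 2 uM (a lower number here means a weaker effect, a higher number a stronger effect of the compound at the concentration tested), compound 1 holds the lowest of the three numbers; compound 2 sits within the scatter of it, and only compound 3 lies beyond it. Compound 4 `Nc1ccccc1NC(=O)c1ccc(CSC(=S)N2CCN(c3ncccn3)CC2)cc1` differs from compound 1 at one place: pyrimidin-2-yl in place of (pyridin-2-yl)methyl on an amine nitrogen in a ring. Among the measured compounds shown here, the single measured step, a number 7 percentage points higher from compound 2 to compound 3 (within the scatter), concerns the group on the thiocarbonyl carbon, not the amine nitrogen in the ring, and it stayed within the scatter. For the measured compounds named here, no measured step touches the position changed here, so nothing points to a direction. The expected step of a number 1.3 percentage points higher from compound 1 to compound 4 (within the scatter) is therefore none beyond the scatter. Compound 4 is estimated at 22% in this assay, between 10% and 36%.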

Compound 4, a percentage reported as inhibition, at one concentration (the size of the read-out at that concentration, not a potency): 24%
The estimate for compound 4 lay 2 percentage points below the measured number; low and high end bracket the measured number.
By their numbers in this assay, from the lowest: compounds 1, 4, 2 and 3 (each within the scatter of the next, the first and the last beyond it).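

In this assay, the first step read at this amine nitrogen in a ring, pyrimidin-2-yl in place of (pyridin-2-yl)methyl, gives a number 3.3 percentage points higher from compound 1 to compound 4 (within the scatter). At this position, then, the two aromatic groups are not told apart, although the ring hetero atoms and the link to the ring nitrogen both differ. No supporting data bear on this result.

On these data alone, both groups at this position are aromatic rings, so a non-aromatic group remains untested in this comparison. As far as these compounds go, whether a longer alkyl chain, a primary amine or a carboxylic acid here would move the number beyond the scatter stays open.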